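Aryl swap on the thiazole: compound 3 to compound 4

This account rests on a few compounds, and the source may have more. Where it says the series, first, only, none or still open, it means among the compounds named here.

Three compounds of the series have numbers in a functional assay on U2OS cells for antagonist activity at C-X-C chemokine receptor type 3 (Homo sapiens), read by beta-arrestin recruitment; on this read-out higher numbers stand for weaker inhibition and lower numbers for stronger inhibition. Compound 1 `C[C@H]1CN(c2scnc2-c2nc3ccccc3[nH]2)CCN1C(=O)Cn1cnc2cccnc21` gives 8030 nM. Compound 2 `Cc1ncc(-c2nc(C(F)(F)F)sc2N2CCN(C(=O)Cn3cnc4cccnc43)[C@H](C)C2)cn1` gives 168 nM. Compound 3 `Cc1ncc(-c2nc(C(F)(F)F)sc2N2CCN(C(=O)Cn3nc(C)nc3C)[C@H](C)C2)cn1` gives 578 nM, the second highest of the three, with compound 2 nearest and compound 1 furthest. Among the measured compounds shown here, the only single-point step known, a 3.4-fold higher number from compound 2 to compound 3 (0.54 log units; beyond the scatter), changes the group on the chain carbon bound to the carbonyl; it does not touch the aryl ring of the shared core. Compound 4 `Cc1nc(C)n(CC(=O)N2CCN(c3sc(C(F)(F)F)nc3-c3ccc(C(F)(F)F)nc3)C[C@H]2C)n1` differs from compound 3 by 6-(trifluoromethyl)pyridin-3-yl in place of 2-methylpyrimidin-5-yl on an aromatic carbon. For the measured compounds named here, no measured pair bears on this change, so the direction is open. Compound 4 is expected to show a step of about a 1.4-fold lower number from compound 3 to compound 4 (0.16 log units; within the scatter), within the scatter, with an estimate of 400 nM (100 nM to 1600 nM) in this assay.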

Compound 4, half-maximal inhibitory concentration: 608 nM
For compound 4 the middle estimate is 1.5-fold (0.18 log units) below the measured one, within the range that was stated.
By their numbers in this assay, from the lowest: compound 2; then compounds 3 and 4 (each within the scatter of the next); then compound 1.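

In this assay the exchange of 2-methylpyrimidin-5-yl for 6-(trifluoromethyl)pyridin-3-yl gives a 1.1-fold higher number from compound 3 to compound 4 (0.02 log units; within the scatter), so the two aryl groups cannot be told apart here. On this aromatic carbon, then, 10 heavy atoms with 1 hydrogen-bond acceptor read the same as 7 heavy atoms with 2, at least alongside the side group shared by compound 3 and compound 4. No measurement on hand accounts for this.

Open, on these data alone, is whether the same aryl exchange reads alike with the side group of compound 2. Also open, as far as these compounds go, is how an amine or a carboxylic acid on this aromatic carbon would read.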